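Chloro added to a fluorophenyl in Vero cytotoxicity

A few compounds are considered here, and "the series" means these few. Any claim that something is new, unique, unknown or untested is made for them only; others in the source may bear on it.

Of the compounds shown here, three sharing one core have been tested in an ADME assay on Vero cells (Chlorocebus sabaeus) for cytotoxicity, read by MTT assay, with a stated time of 72 h; on this read-out lower numbers stand for higher toxicity in this test and higher numbers for lower toxicity in this test. Compound 1 `C[C@]1(CN2CCc3nc(-c4ccc(F)cc4)oc3C2)Cn2cc([N+](=O)[O-])nc2O1` sits at the limit of the test: in this assay compound 1 gives > 32 ug/mL, a limit rather than a number. Compound 2 `C[C@]1(CN2CCc3oc(-c4ccc(F)cc4)nc3C2)Cn2cc([N+](=O)[O-])nc2O1` also reaches only a limit, and in this assay compound 2 gives > 32 ug/mL. Compound 3 `C[C@]1(CN2CCc3nc(-c4cccc(F)c4)ccc3C2)Cn2cc([N+](=O)[O-])nc2O1` is no different in kind: in this assay compound 3 gives > 32 ug/mL, again a limit and not a measured number. Compound 3 therefore stands where every compound shown stands, at the limit of > 32 ug/mL in this assay, at which 3 of the 3 values shown sit, so no order among the three can be read from these figures.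

Compound 4 `C[C@]1(CN2CCc3nc(-c4ccc(Cl)c(F)c4)ccc3C2)Cn2cc([N+](=O)[O-])nc2O1` differs from compound 3 by chloro in place of hydrogen on an aromatic carbon. For the measured compounds named here, no step between measured compounds is available, and the three limits give no direction to expect. Compound 4 is therefore expected to show a step that the limit leaves unreadable from compound 3 to compound 4 in this assay, nothing beyond the scatter. Compound 4 is estimated to give 40 ug/mL in this assay, expected to lie between 20 ug/mL and 80 ug/mL, most likely again reported as a limit.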

Compound 4, half-maximal cytotoxic concentration: > 32 ug/mL
Compound 4 gave a limit, no number; the forecaster's own chance of this, stated with the estimate: 75%; the middle value lies beyond the limit too.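

No step from compound 3 to compound 4 can be read, as both compounds give only a limit and no number: the limit of > 32 ug/mL in this assay, at which 4 of the 4 values shown sit.

The compounds shown leave open whether chloro in place of hydrogen alters the read-out in this assay, and how the four compounds rank against one another.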